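The compounds below may be only part of what the source reports. "The series", "measured", "known", "first", "only" and "open" are said of these compounds alone.

In an assay on cells for displacement of a labelled ligand from 5-hydroxytryptamine receptor 1D (Homo sapiens), read by scintillation counting, with a stated time of 90 min (on this read-out higher numbers stand for weaker inhibition and lower numbers for stronger inhibition), compound 1 `Cc1ncc2nccn2c1-c1ccc(Oc2nccc3occc23)cc1C(F)(F)F` gives 8100 nM and compound 2 `FC(F)(F)c1cc(Oc2nccc3occc23)ccc1-c1cccc2nccn12` gives 8900 nM. The step is a 1.1-fold higher number from compound 1 to compound 2 (0.04 log units; within the scatter), so compound 2 stands level with compound 1 on the two numbers available. Compound 3 `FC(F)(F)c1cc(Oc2nccc3ccsc23)ccc1-c1cccc2nccn12` differs from compound 2 by a group of 9 heavy atoms (7 carbon, 1 nitrogen, 1 sulfur; one five-membered aromatic ring with 1 hetero atom, one six-membered aromatic ring with 1 hetero atom) in place of a group of 9 heavy atoms (7 carbon, 1 nitrogen, 1 oxygen; one five-membered aromatic ring with 1 hetero atom, one six-membered aromatic ring with 1 hetero atom), on an oxygen on an aromatic ring. Going by the values given here, no measured step touches this part of the molecule; the single known step alters the other end of the shared core and offers no pointer to a shift in this assay beyond the scatter. For compound 3 the expected step is no change at the digits printed from compound 2 to compound 3 (within the scatter). Compound 3 is therefore estimated at 8900 nM, with a range from 3500 nM to 22000 nM.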

Compound 3, inhibition constant: 4100 nM
For compound 3 the middle estimate is 2.2-fold (0.34 log units) above the measured one; measured number inside the range.
By their numbers in this assay, from the lowest: compounds 3, 1 and 2 (each within the scatter of the next, the first and the last beyond it).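

In this assay, going by these compounds alone, the group on the oxygen on an aromatic ring proves sensitive to one hetero atom: sulfur in place of oxygen in its five-membered aromatic ring gives a 2.2-fold lower number from compound 2 to compound 3 (0.34 log units; beyond the scatter), the first step here beyond the scatter. The groups match in heavy-atom, donor and acceptor counts, so the two compounds differ only by that atom. Nothing measured here accounts for the shift. As far as these compounds go, it remains open whether a simple phenyl group or an amine-bearing group at this place would move the number further. From the compounds shown here alone, it is also open whether sulfur would give a similar step with the other group carried by compound 1.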